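Methoxy to pyrazolyl swap on the shared core: agonist notes

A few compounds are considered here, and "the series" means these few. Any claim that something is new, unique, unknown or untested is made for them only; others in the source may bear on it.

compound 1 `COc1c(Cl)ccc2c1CCC2c1ncc[nH]1`: > 10000 nM
compound 2 `Cc1c(OCC2=NCCN2)ccc(Cl)c1NS(C)(=O)=O`: > 10000 nM
compound 3 `CCS(=O)(=O)Nc1cccc2c1CCC2c1ncc[nH]1`: > 10000 nM

Compound 1 `COc1c(Cl)ccc2c1CCC2c1ncc[nH]1` gives in a functional assay on CHO cells for agonist activity at Alpha-1B adrenergic receptor (Homo sapiens), read by FLIPR and calcium flux (a higher number here means that more compound is needed for the effect, a lower number that less compound is needed), only a limit, > 10000 nM, and not a number. Compound 2 `Cc1c(OCC2=NCCN2)ccc(Cl)c1NS(C)(=O)=O` in this assay likewise returns a limit, > 10000 nM. Compound 3 `CCS(=O)(=O)Nc1cccc2c1CCC2c1ncc[nH]1` in this assay also returns a limit, > 10000 nM. All three values sit at the same ceiling of the assay, (the limit of > 10000 nM in this assay, at which 3 of the 3 values shown sit). Compound 1 therefore stands at that limit with no number of its own, and nothing in the measured set separates it from compound 2 or compound 3.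

Compound 4 `Clc1ccc2c(c1-c1ccn[nH]1)CCC2c1ncc[nH]1` has not been measured in this assay. Relative to compound 1 it differs by 1H-pyrazol-5-yl in place of methoxy on an aromatic carbon. Among the measured compounds shown here, no pair of measured compounds shows how a change of this kind moves the read-out, so no step size can be taken from the series itself. Since compound 1 only reaches the limit > 10000 nM, the change from compound 1 to compound 4 is expected to stay near that ceiling, with the estimated step of an at least 1.1-fold lower number from compound 1 to compound 4 (0.04 log units; that floor lies within the scatter) carrying little weight either way. Compound 4 is expected to give about 9000 nM in this assay, within a range from 2000 nM to 30000 nM, and most likely again only a limit.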

Compound 4, half-maximal effective concentration: > 10000 nM
Compound 4: no number, only a limit (the forecaster's own chance of this, stated with the estimate: 70%); middle value at least 1.1-fold (0.04 log units) away from the limit.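

Compound 4 gives > 10000 nM in this assay, which is a limit and not a number. No step can be read from compound 1 to compound 4 because both stand at the same limit: the limit of > 10000 nM in this assay, at which 4 of the 4 values shown sit.

The compounds shown leave open whether 1H-pyrazol-5-yl in place of methoxy moves the read-out at all, and what numerical value any of these compounds would give.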